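Can 1,1-Difluoroethyl Bring Clearance Back Down?

The source may hold more compounds than are shown below. What is called first, only, known or untested is meant among the compounds shown, and "the series" means these compounds.

In an in vitro ADME assay on microsomes from liver (Mus musculus) for metabolic stability (on this read-out higher numbers stand for fast clearance and lower numbers for slow clearance), compound 1 `Cc1cc(Nc2ccc(S(F)(F)(F)(F)F)cc2)n2nc(C(F)(F)F)nc2n1` gives < 6 mL.min-1.g-1 as a limit of the assay, not a number. For the measured compounds named here, compound 2 `COCc1nc2nc(C)cc(Nc3ccc(S(F)(F)(F)(F)F)cc3)n2n1` gives 14.3 mL.min-1.g-1 and is the only compound with an actual number so far. Compound 3 `Cc1cc(Nc2ccc(S(F)(F)(F)(F)F)cc2)n2nc(C(C)(F)F)nc2n1` carries 1,1-difluoroethyl in place of methoxymethyl on an aromatic carbon on that same aromatic carbon. Going by the values given here, the one measured step that bears on this is an at least 2.3-fold higher number from compound 1 to compound 2 (0.37 log units; beyond the scatter) on putting methoxymethyl in place of trifluoromethyl, so returning to a fluorinated group is expected to lower the number. The expected change is a 2.0-fold lower number from compound 2 to compound 3 (0.31 log units; beyond the scatter) in this assay and may stay close to the scatter. The expected value for compound 3 is 7 mL.min-1.g-1 with 4 mL.min-1.g-1 to 15 mL.min-1.g-1 as its estimated range.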

Compound 3, intrinsic clearance in microsomes in the liver assay: 8.1 mL.min-1.g-1
For compound 3 the middle estimate is 1.2-fold (0.06 log units) below the measured one; measured number inside the range.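

In the liver assay, 1,1-difluoroethyl in place of methoxymethyl on this aromatic carbon gives a 1.8-fold lower number from compound 2 to compound 3 (0.25 log units; within the scatter), so compound 2 and compound 3 cannot be told apart on this read-out. The same change does register in a physicochemical assay for lipophilicity, at pH 7.4; on this read-out lower numbers stand for lower lipophilicity and higher numbers for higher lipophilicity: the measured distribution coefficient of compound 2, 2.8, and of compound 3, 3.6, a number 0.80 log units higher (beyond the scatter). In the physicochemical assay compound 2 gives 2.8 and compound 3 gives 3.6. In the liver assay compound 1 gives < 6 mL.min-1.g-1, which is a limit of the assay and not a number.

Read against that limit in the liver assay, the step is an at least 1.3-fold higher number from compound 1 to compound 3 (0.13 log units; that floor lies within the scatter), so the true size of the step from methyl in place of fluoro stays open. As far as these compounds go, how an amine or a longer chain on this aromatic carbon would behave in either assay also remains open.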